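The compounds below may be only part of what the source reports. "The series", "measured", "known", "first", "only" and "open" are said of these compounds alone.

Measured compounds in the series:

compound 1 `C/N=C(\S)NCCCCCn1nc(-c2ccccc2)ccc1=O`: in a functional assay on the whole organism (stomach) with Rattus norvegicus as the target (on this read-out lower numbers stand for an effect already at smaller amounts and higher numbers for an effect only at larger amounts of compound), compound 1 gives 35.3 mg/kg.
compound 2 `C/N=C(/NC#N)NCCCCCn1nc(-c2ccccc2)ccc1=O`: in this assay compound 2 gives 100 mg/kg.
compound 3 `CCC/N=C(/NC#N)NCCCCCn1nc(-c2ccccc2)ccc1=O`: in this assay compound 3 gives only a limit of the assay, > 100 mg/kg.

Compound 3 thus stands at the edge of what the assay reports, (the limit of > 100 mg/kg in this assay, at which 1 of the 3 values shown sits), and its distance from the other two compounds is open. The unmeasured compound 4 `CC/N=C(/NC#N)NCCCCCn1nc(-c2ccccc2)ccc1=O` is reached from compound 3 by hydrogen in place of methyl on a saturated chain carbon, two bonds along the chain from a double-bonded nitrogen. The step nearest in kind is a number no lower from compound 2 to compound 3 (the limit leaves the size open), whose size cannot be read off since compound 3 is a limit. The remaining steps, a 2.8-fold higher number from compound 1 to compound 2 (0.45 log units; beyond the scatter) and an at least 2.8-fold higher number from compound 1 to compound 3 (0.45 log units; beyond the scatter), both run away from compound 1 and say nothing about how the chain length within the cyanoguanidine set shifts the number. Compound 4 sits between compound 2 and compound 3 in chain length, so in this assay the expectation for compound 4 is a number close to that of compound 2, with a fair chance that the assay again returns only a limit; a number no higher from compound 3 to compound 4 (the limit leaves the size open) is expected to be small or not readable. Compound 4 is estimated at 100 mg/kg, within 55 mg/kg to 200 mg/kg.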

Compound 4, dose for half-maximal effect: 100 mg/kg
Beside the measured number, compound 4's estimate shows no gap at the digits printed, and the stated range covers the measured number.
By their numbers in this assay, from the lowest: compound 1; then compounds 2 and 4 (each within the scatter of the next).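

In this assay, methyl in place of hydrogen on a saturated chain carbon bound to a double-bonded nitrogen gives no change at the digits printed from compound 2 to compound 4 (within the scatter), so the first extension of the chain on the cyanoguanidine nitrogen has a readable outcome, which compound 3 alone could not provide. The separation from the sulfur-bearing compound also holds for the extended chain, with a 2.8-fold higher number from compound 1 to compound 4 (0.45 log units; beyond the scatter), a step of the same printed size as a 2.8-fold higher number from compound 1 to compound 2 (0.45 log units; beyond the scatter). Compound 3 gives only a limit of the assay, so hydrogen in place of methyl on a saturated chain carbon, two bonds along the chain from a double-bonded nitrogen, gives a number no higher from compound 3 to compound 4 (the limit leaves the size open), and the loss of a methyl group at this position has no measurable size, because the value of compound 3 sits at the edge of the read-out: the limit of > 100 mg/kg in this assay, at which 1 of the 4 values shown sits.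

The compounds shown leave open whether a butyl chain, a longer chain or a branched group such as isopropyl on this nitrogen would give a readable number in this assay. On these data alone, it is also open whether ethyl or propyl in place of the methyl group of compound 1, on the sulfur-bearing group, would shift the number there, or would again leave it unchanged within the scatter.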